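The source may report more compounds than this note shows. Statements on the series, on what has been measured and on what is new or still open speak of the compounds shown alone.

Three compounds have a number in a physicochemical assay for lipophilicity (a higher number here means a more lipophilic compound, a lower number a more polar compound), so far:

Compound 1, `C=C1CC[C@@H]2[C@](C)(CO[C@@H]3O[C@H](CO)[C@@H](O)[C@H](O)[C@H]3O)CCC[C@@]2(C)[C@@H]1CCC1=CCOC1=O`, gives 3.07.
Compound 2, `C=C1CC[C@@H]2[C@](C)(CO)[C@H](O)CC[C@@]2(C)[C@@H]1C/C=C1\C=COC1=O`, gives 3.28.
Compound 3, `C=C1CC[C@@H]2[C@](C)(COC(C)=O)[C@H](OC(C)=O)CC[C@@]2(C)[C@@H]1C/C=C1\C=COC1=O`, gives 3.87.

Of these three numbers, compound 3 holds the highest. Its nearest neighbour is compound 2, which sits lower by a gap that is beyond the scatter, and compound 1 lies further still, also beyond the scatter. Going by the values given here, no two of the measured compounds differ from one another in a single place, so no single step within this set can be read off directly; only the values themselves can be compared.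

Compound 4, `C=C1CC[C@@H]2[C@](C)(COC(C)=O)[C@H](OC(C)=O)CC[C@@]2(C)[C@@H]1/C=C/C1=CCOC1=O`, has not yet been measured in this assay. It holds the same atoms as compound 3, joined differently: a group of 8 heavy atoms (6 carbon, 2 oxygen; one five-membered non-aromatic ring with 1 hetero atom) in place of a group of 8 heavy atoms (6 carbon, 2 oxygen; one five-membered non-aromatic ring with 1 hetero atom), on a saturated ring carbon. The group that leaves and the group that enters are alike in their counts of carbon and oxygen, in their single five-membered ring with one hetero atom, in their double bonds and in their acceptors, and the rest of the molecule is unchanged.

On that basis no step beyond the scatter is expected. The step from compound 3 to compound 4 is estimated at a number 0.02 log units lower from compound 3 to compound 4 (within the scatter), and compound 4 is expected to give 3.85, within a range from 3.45 to 4.25.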

Compound 4, partition coefficient: 3.83
For compound 4 the middle estimate is 0.02 log units above the measured one; low and high end bracket the measured number.
By their numbers in this assay, from the lowest: compounds 1 and 2 (each within the scatter of the next); then compounds 4 and 3 (each within the scatter of the next).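

Compound 4 gives this set its first step at a single place in this assay, and that step is a number 0.04 log units lower from compound 3 to compound 4 (within the scatter). At this saturated ring carbon, then, one group of 8 heavy atoms (6 carbon, 2 oxygen; one five-membered non-aromatic ring with 1 hetero atom) can stand in for another of the same counts, with the same atoms joined differently, and the result cannot be told apart from compound 3 in this read-out. There are no further measurements that could explain this outcome.

The pair leaves open whether the position stays this insensitive when the atoms themselves change, for instance if a group at this place carries an amine or a carboxylic acid, or has a longer chain between the ring carbon and the five-membered ring. It also leaves open whether the same exchange would give a step within the scatter on the core of compound 2, with its free hydroxyl groups in place of the acetates.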